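Bromo in Place of Hydrogen on a Shared Core

The compounds below may be only part of what the source reports. "The series", "measured", "known", "first", "only" and "open" are said of these compounds alone.

Measured so far:
compound 1 `CC(C)c1ccc(NCC(=O)N[C@H]2CCOC2=O)cc1`: > 64000 nM
compound 2 `O=C(CNc1ccccc1)N[C@H]1CCOC1=O`: > 64000 nM

In a functional assay on MGC-803 cells (Homo sapiens) for antiproliferative activity, read by MTT assay, with a stated time of 72 h (a higher number here means a weaker inhibitor, a lower number a stronger inhibitor), compound 1 gives only a limit, > 64000 nM. Compound 2 likewise reaches only a limit, > 64000 nM. The step from compound 1 to compound 2 is therefore a step that the two limits leave unreadable from compound 1 to compound 2. Compound 2 thus stands at the limit of > 64000 nM in this assay, at which 2 of the 2 values shown sit, with no number to place it. Compound 3 `O=C(CNc1ccc(Br)cc1)N[C@H]1CCOC1=O` differs from compound 2 by bromo in place of hydrogen on an aromatic carbon. Among the measured compounds shown here, the one measured step cannot guide this change, as both of its ends sit at the limit, so no direction can be drawn. Compound 3 is therefore expected near 80000 nM (range 20000 nM to 300000 nM), an expected step that the limit leaves unreadable from compound 2 to compound 3.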

Compound 3, half-maximal inhibitory concentration: > 64000 nM
Compound 3: a limit, no number; the forecaster's own chance of this, stated with the estimate: 75%; the middle value is on the limit's open side.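

Among the compounds shown here, compound 3 also gives only a limit, > 64000 nM, so no step among compound 1, compound 2 and compound 3 can be read: the limit of > 64000 nM in this assay, at which 3 of the 3 values shown sit. The compounds shown leave open whether bromo, isopropyl or hydrogen on that aromatic carbon makes any difference in this assay.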